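The source may hold more compounds than are shown below. What is called first, only, known or untested is meant among the compounds shown, and "the series" means these compounds.

Measured so far in an ADME assay on HepG2 cells (Homo sapiens) for cytotoxicity, read by MTT assay, with a stated time of 72 h; a higher number here means that more compound is tolerated, a lower number that less compound is tolerated:
- Compound 1 `O=[N+]([O-])c1c(CS(=O)(=O)c2ccccc2)nc2c(-c3ccc(CO)cc3)cc(Cl)cn12`: 13100 nM
- Compound 2 `O=[N+]([O-])c1c(CS(=O)(=O)c2ccccc2)nc2c(-c3cccc(CO)c3)cc(Cl)cn12`: > 25000 nM, a limit
- Compound 3 `O=[N+]([O-])c1c(CS(=O)(=O)c2ccccc2)nc2c(-c3cccc(F)c3)cc(Cl)cn12`: > 12500 nM, a limit

Compound 3 has no number in this assay, only the limit > 12500 nM. Compound 4 `O=[N+]([O-])c1c(CS(=O)(=O)c2ccccc2)nc2c(-c3ccncc3)cc(Cl)cn12` differs from it by pyridin-4-yl in place of 3-fluorophenyl on an aromatic carbon, with pyridin-4-yl in place of 3-fluorophenyl on an aromatic carbon. For the measured compounds named here, no measured step makes this exchange, and the steps that change the group at this place give little size to work from. They are a step that the limit leaves unreadable from compound 1 to compound 3 and a step that the two limits leave unreadable from compound 2 to compound 3. Going by the values given here, the only step with a readable floor is an at least 1.9-fold higher number from compound 1 to compound 2 (0.28 log units; that floor lies within the scatter). None of the three is shown beyond the scatter, so no step beyond the scatter is expected in this assay, in either direction. Among the compounds with values here, the one true number, compound 1 at 13100 nM, anchors the expectation. Compound 4 is expected at about 14000 nM, with an estimated range of 6000 nM to 30000 nM. The expected step is a step that the limit leaves unreadable from compound 3 to compound 4.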

Compound 4, half-maximal cytotoxic concentration: > 50000 nM
Compound 4: no number, only a limit; the forecaster's own chance of this, stated with the estimate: 50%; middle value at least 3.5-fold (0.55 log units) away from the limit.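

In this assay, for the compounds shown here, pyridin-4-yl at this place, ortho to a fused ring, gives the first step that clears the scatter: an at least 3.8-fold higher number from compound 1 to compound 4 (0.58 log units; beyond the scatter). Compound 4 has only a limit, not a number: the limit of > 50000 nM in this assay, at which 1 of the 4 values shown sits. Going by these compounds alone, the steps to compound 4 from compound 2 and compound 3 cannot be read, as both ends of each are limits, so the exchange of 3-fluorophenyl for pyridin-4-yl has no size here, and the one readable change is measured against 4-(hydroxymethyl)phenyl alone.

As far as these compounds go, how far compound 4 lies past its limit in this assay remains open. Also open, from the compounds shown here alone, is how a pyridin-3-yl group, or a phenyl ring carrying an amine, would stand at this place.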